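The source may hold more compounds than are shown below. What is called first, only, known or untested is meant among the compounds shown, and "the series" means these compounds.

Compounds measured so far:
Compound 1 `NC(=O)[C@@H](CCC(F)(F)F)N(C[C@H]1CCCOC1)S(=O)(=O)c1ccc(Cl)cc1`: 18.2 10^-6 cm/s
Compound 2 `NC(=O)[C@@H](CCC(F)(F)F)N(C[C@@H]1CCCOC1)S(=O)(=O)c1ccc(Cl)cc1`: 18.4 10^-6 cm/s

In an ADME assay on MDCKII-LE cells (Canis lupus familiaris) for permeability, read by transwell migration, in the apical to basolateral direction (on this read-out higher numbers stand for higher permeability and lower numbers for lower permeability), compound 1 gives 18.2 10^-6 cm/s and compound 2 gives 18.4 10^-6 cm/s. For the measured compounds named here, the only measured step, a 1.0-fold higher number from compound 1 to compound 2 (0.00 log units; within the scatter), is flat; it rests on (the fact that compounds 1 and 2 differ only in the configuration as drawn). Compound 2 therefore stands level with compound 1, with no separation beyond the scatter between the two numbers.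

Compound 3 `NC(=O)[C@@H](CCC(F)(F)F)N(C[C@H]1COCCO1)S(=O)(=O)c1ccc(Cl)cc1` carries 1,4-dioxan-2-yl in place of oxan-3-yl on a saturated chain carbon bound to a sulfonamide nitrogen. Going by the values given here, no measured step touches this change: the step from compound 1 to compound 2 altered only the drawn configuration at the ring and left the ring itself intact, so it offers no guide to exchanging one saturated ring for another. Without any bearing step, the expectation for compound 3 is a small change at most, a 1.3-fold lower number from compound 2 to compound 3 (0.12 log units; within the scatter), leaning slightly lower but within the usual scatter. Compound 3 is thus expected to give about 14 10^-6 cm/s, in a range from 7 10^-6 cm/s to 26 10^-6 cm/s.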

Compound 3, apparent permeability: 20.6 10^-6 cm/s
The estimate for compound 3 lay 1.5-fold (0.17 log units) below the measured number; the range from low to high includes it.
By their numbers in this assay, from the lowest: compounds 1, 2 and 3 (each within the scatter of the next).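

In this assay, the exchange of oxan-3-yl for 1,4-dioxan-2-yl on a saturated chain carbon bound to a sulfonamide nitrogen is flat, with a 1.1-fold higher number from compound 2 to compound 3 (0.05 log units; within the scatter) and a 1.1-fold higher number from compound 1 to compound 3 (0.05 log units; within the scatter). The earlier compounds shown here showed this only for the drawn configuration at the ring; this result shows that a ring with 2 hetero atoms can stand where one with 1 hetero atom stood without the number leaving the scatter, against either configuration of oxan-3-yl. Nothing measured here accounts for this flatness.

As far as these compounds go, whether a group of another kind at this place, such as an amine or a longer chain, would move the number remains open. So does the effect on this read-out of the other drawn configuration of 1,4-dioxan-2-yl.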